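The source may report more compounds than this note shows. Statements on the series, on what has been measured and on what is new or still open speak of the compounds shown alone.

Series in a functional assay on NALM-6 cells (Homo sapiens) for cytotoxicity, read by luminescence and CellTiter-Glo, with a stated time of 3 days; on this read-out lower numbers stand for stronger inhibition and higher numbers for weaker inhibition:
- compound 1 `O=C(Nc1ccc(Cl)cc1Cl)c1ccc2cccnc2c1O`: 450 nM
- compound 2 `N#Cc1ccc(NC(=O)c2ccc3cccnc3c2O)cc1`: 130 nM
- compound 3 `O=C(Nc1ccc(C(F)(F)F)cc1)c1ccc2cccnc2c1O`: 380 nM

Compound 3, at 380 nM, lies within the scatter of compound 1 and is separated from compound 2 by a 2.9-fold higher number from compound 2 to compound 3 (0.47 log units; beyond the scatter). Next is compound 4 `O=C(Nc1ccc(Cl)cc1)c1ccc2cccnc2c1O`: chloro in place of trifluoromethyl on an aromatic carbon, chloro in place of trifluoromethyl, para to a large group. Within the data shown here, the one measured step at this place is that modest a 2.9-fold higher number from compound 2 to compound 3 (0.47 log units; beyond the scatter). Compound 1, with chloro there plus a second chloro, gives 450 nM, within the scatter of compound 3. The expected result is a 1.1-fold lower number from compound 3 to compound 4 (0.04 log units; within the scatter), with no change beyond the scatter anticipated. For compound 4 the estimate is 350 nM, with an expected range of 170 nM to 700 nM.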

Compound 4, half-maximal inhibitory concentration: 380 nM
Compound 4: the middle estimate sits 1.1-fold (0.04 log units) below what was measured; the measured number falls inside the stated range.
By their numbers in this assay, from the lowest: compound 2; then compounds 3, 4 and 1 (each within the scatter of the next).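

Chloro in place of trifluoromethyl at this position leaves the number unmoved (no change at the digits printed from compound 3 to compound 4 (within the scatter)), whereas chloro in place of cyano raises it (a 2.9-fold higher number from compound 2 to compound 4 (0.47 log units; beyond the scatter)), so among compounds 2, 3 and 4 only compound 2 stands apart. Hydrogen in place of the second chloro (a 1.2-fold lower number from compound 1 to compound 4 (0.07 log units; within the scatter)) gives no change beyond the scatter.

From the compounds shown here alone, whether an amine, a carboxylic acid or plain hydrogen at this position would group with compound 2 or with compounds 3 and 4 stays open. No measured evidence bears on the reason for these results.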